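Swapping the aromatic arm of compound 3 for tert-butoxycarbonyl

The source may report more compounds than this note shows. Statements on the series, on what has been measured and on what is new or still open speak of the compounds shown alone.

Measured so far:
Compound 1 `Cc1ncc([N+](=O)[O-])n1CC(O)CSC(=S)N1CCN(c2cccc(Cl)c2Cl)CC1` gives 1000000 nM in a toxicity assay on HeLa cells (Homo sapiens) for cytotoxicity, read by MTT assay, with a stated time of 24 h; on this read-out lower numbers stand for stronger inhibition and higher numbers for weaker inhibition.
Compound 2 `Cc1ncc([N+](=O)[O-])n1CC(O)Cn1ccnn1` reaches only a limit of this assay, > 5000000 nM.
Compound 3 `Cc1nc([N+](=O)[O-])cn1CC(O)CSC(=S)N1CCN(c2cccc(Cl)c2Cl)CC1` gives 724000 nM in this assay.

Among the measured compounds shown here, compound 3 and compound 1 lie within the scatter of each other: the only measured step is a 1.4-fold lower number from compound 1 to compound 3 (0.14 log units; within the scatter), a nitro shift on the shared core. Compound 4 `Cc1nc([N+](=O)[O-])cn1CC(O)CSC(=S)N1CCN(C(=O)OC(C)(C)C)CC1` is not yet measured. It differs from compound 3 by tert-butoxycarbonyl in place of 2,3-dichlorophenyl on an amine nitrogen in a ring. For the measured compounds named here, no measured step touches this position; the single step recorded concerns a different part of the molecule, and compound 2, which lacks the whole side arm, sits at a limit (the limit of > 5000000 nM in this assay, at which 1 of the 3 values shown sits). The expectation for compound 4 in this assay is therefore a step of a 1.4-fold higher number from compound 3 to compound 4 (0.14 log units; within the scatter), with wide uncertainty. Compound 4 is estimated at 1000000 nM, between 250000 nM and 5000000 nM.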

Compound 4, half-maximal inhibitory concentration: > 5000000 nM
Compound 4: no number, only a limit; the forecaster's own chance of this, stated with the estimate: 30%; at least 5.0-fold (0.69 log units) between middle value and limit.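

In this assay, the ring nitrogen's arm proves to be a position that can shift the read-out: tert-butoxycarbonyl in place of 2,3-dichlorophenyl gives an at least 6.9-fold higher number from compound 3 to compound 4 (0.83 log units; beyond the scatter), the only step shown that lies beyond the scatter. Compound 4 gives a limit, not a number, and so does compound 2: the limit of > 5000000 nM in this assay, at which 2 of the 4 values shown sit.

Still open, from the compounds shown here alone, is whether the aromatic ring itself or its chlorine atoms accounts for the measurable value of compound 3, a question that a plain phenyl group on that nitrogen could address. Going by these compounds, whether the same swap acts alike on compound 1 also remains open.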